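Amide variation on a shared trimethoxyphenyl benzylamide core

A few compounds are considered here, and "the series" means these few. Any claim that something is new, unique, unknown or untested is made for them only; others in the source may bear on it.

Measured so far in a functional assay on HCT-116 cells (Homo sapiens) for inhibition, read by MTT assay, with a stated time of 48 h; a higher number here means a weaker inhibitor, a lower number a stronger inhibitor:
- compound 1 `COc1ccc(CN(C(=O)C[Se]C#N)c2cc(OC)c(OC)c(OC)c2)cc1O` gives 310 nM
- compound 2 `COc1ccc(CN(C(=O)C=C(C)C)c2cc(OC)c(OC)c(OC)c2)cc1O` gives 290 nM
- compound 3 `COc1ccc(CN(C(=O)CN=[N+]=[N-])c2cc(OC)c(OC)c(OC)c2)cc1O` gives 410 nM

Compound 3 holds the highest of the three numbers, yet its nearest neighbour is compound 1 at a 1.3-fold higher number from compound 1 to compound 3 (0.12 log units; within the scatter) and its furthest is compound 2 at a 1.4-fold higher number from compound 2 to compound 3 (0.15 log units; within the scatter); both gaps are within the scatter, so the three compounds are not separated by this assay. Likewise the exchange on the carbonyl carbon gives a 1.1-fold lower number from compound 1 to compound 2 (0.03 log units; within the scatter), again within the scatter.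

Compound 4 `C/C=C/C(=O)N(Cc1ccc(OC)c(O)c1)c1cc(OC)c(OC)c(OC)c1` differs from compound 3 as follows:

prop-1-en-1-yl in place of azidomethyl on a carbonyl carbon

Among the compounds with values here, the step that bears most directly on this change is the one to compound 3 from compound 2, where an alkenyl group was replaced by azidomethyl on the same carbonyl carbon and the number moved by a 1.4-fold higher number from compound 2 to compound 3 (0.15 log units; within the scatter), within the scatter. Compound 4 puts an alkenyl group, prop-1-en-1-yl, back in that position. The expectation is therefore a small move back toward the number of compound 2, i.e. a step of a 1.4-fold lower number from compound 3 to compound 4 (0.14 log units; within the scatter), not beyond the scatter. Compound 4 is estimated at 300 nM in this assay, with a range of 150 nM to 600 nM.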

Compound 4, half-maximal inhibitory concentration: 55 nM
The estimate for compound 4 lay 5.5-fold (0.74 log units) above the measured number; the whole stated range lies above it.
By their numbers in this assay, from the lowest: compound 4; then compounds 2, 1 and 3 (each within the scatter of the next).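

In this assay, the group on the carbonyl carbon, whose amide-type nitrogen is held constant, turns out to separate compounds after all: the earlier exchanges stayed within the scatter, whereas prop-1-en-1-yl gives steps beyond it against azidomethyl (a 7.5-fold lower number from compound 3 to compound 4 (0.87 log units; beyond the scatter)) and against the selenium-bearing group of compound 1 (a 5.6-fold lower number from compound 1 to compound 4 (0.75 log units; beyond the scatter)). The most telling comparison is with the other alkenyl group, 2-methylprop-1-en-1-yl (a 5.3-fold lower number from compound 2 to compound 4 (0.72 log units; beyond the scatter)), which shows that an alkenyl group at this place is not sufficient in itself, since compound 2 stays within the scatter of compounds 1 and 3. No accompanying measurement bears on the origin of these steps.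

On these data alone, whether the double bond of prop-1-en-1-yl is required remains open, and a saturated propyl chain on the same carbonyl carbon would address that directly. How much room this place allows is also unsettled, as neither a longer unbranched chain nor a cyclopropyl ring appears among these compounds to show whether the lower number persists.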